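This account rests on a few compounds, and the source may have more. Where it says the series, first, only, none or still open, it means among the compounds named here.

Compound 1 `O=C(OC1CCCCC1)c1ccc(NCc2cncn2Cc2ccc(-c3ccccc3)cc2)cc1-c1ccccc1` was tested in a toxicity assay on NIH3T3 cells (Mus musculus) for cytotoxicity, read by resazurin assay; on this read-out higher numbers stand for an effect only at larger amounts of compound and lower numbers for an effect already at smaller amounts. In this assay compound 1 reached only the assay limit of > 10000 nM, not a number. That limit is the one described as the limit of > 10000 nM in this assay, at which 1 of the 3 values shown sits. Compound 1 therefore stands at the edge of what the assay reports, with a limit rather than a value to place it among the others. Two further compounds were measured alongside it. Compound 2 `CC(C)c1cccc(NCc2cncn2Cc2ccccc2)c1` also reached only a limit in this assay, > 1000 nM, the one described as the limit of > 1000 nM in this assay, at which 1 of the 3 values shown sits. Compound 3 `COC(=O)c1ccc(NCc2cncn2Cc2ccccc2Br)cc1-c1ccccc1` gave a number, 10000 nM, in this assay. Within the data shown here, no pair among the three differs in a single place, so no measured step can be drawn from them. Compound 4 `CCC(=O)c1ccc(NCc2cncn2Cc2ccc(-c3ccccc3)cc2)cc1-c1ccccc1` has not yet been measured. It differs from compound 1 in one place: ethyl in place of cyclohexyloxy on a carbonyl carbon. Among the measured compounds shown here, with no measured step to guide it, the expected step of a number no higher from compound 1 to compound 4 (the limit leaves the size open) is none beyond the scatter. This expectation rests on compound 1, which sits at its limit of > 10000 nM. It also takes into account that compound 3 gives 10000 nM. For compound 4 a half-maximal effective concentration of 10000 nM is estimated, expected to fall between 3000 nM and 30000 nM, with a fair chance that only a limit is returned once more.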

Compound 4, half-maximal effective concentration: > 10000 nM
Compound 4 gave a limit, no number; the forecaster's own chance of this, stated with the estimate: 50%; the middle value sits exactly at the limit.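

Compound 1 and compound 4 both returned only a limit of the assay and no number, so no step can be read between them for ethyl in place of cyclohexyloxy on a carbonyl carbon. The compounds shown leave open where the true half-maximal effective concentration of either compound lies in this assay.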